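The source may hold more compounds than are shown below. What is called first, only, known or untested is meant among the compounds shown, and "the series" means these compounds.

Measured compounds:
- compound 1 `O=C(O)C(CCC/C=C(\c1ccccc1)c1cccnc1)Sc1ccccc1`: 33 nM
- compound 2 `O=C(O)C(CCC/C=C(\c1cccnc1)c1cccs1)c1ccccc1`: 50 nM

Both compounds were tested in an assay (Equus caballus) for inhibition of Thromboxane-A synthase (Homo sapiens), using microsomes; on this read-out higher numbers stand for weaker inhibition and lower numbers for stronger inhibition. Compound 1 gives 33 nM and compound 2 gives 50 nM. Compound 1 has the lower of the two numbers, yet its gap to compound 2 lies within the scatter, so the two cannot be told apart on this read-out.

Compound 3 `O=C(O)C(CCC/C=C(\c1ccccc1)c1cccnc1)C1(O)CCCC1` has not yet been measured in this assay. It is derived from compound 1 by one change: 1-hydroxycyclopentyl in place of phenylsulfanyl on a saturated chain carbon bound to a carbonyl carbon and a saturated chain carbon. Among the measured compounds shown here, no measured pair in this set shows what such a change does, so no step size is known here. The expectation for compound 3 is that the step of a 1.8-fold higher number from compound 1 to compound 3 (0.26 log units; within the scatter) is modest and slightly towards a higher number, though a result anywhere within the scatter of compound 1 would not surprise. Compound 3 is therefore estimated at 60 nM, with a range from 15 nM to 250 nM.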

Compound 3, half-maximal inhibitory concentration: 65 nM
Beside the measured number, compound 3's estimate is 1.1-fold (0.03 log units) below it; the measured number falls inside the stated range.
By their numbers in this assay, from the lowest: compounds 1, 2 and 3 (each within the scatter of the next).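

Replacing phenylsulfanyl with 1-hydroxycyclopentyl on the saturated chain carbon bound to a carbonyl carbon and a saturated chain carbon gives a 2.0-fold higher number from compound 1 to compound 3 (0.29 log units; within the scatter) in this assay, so this assay does not tell the two compounds apart. In this one pair, neither the six-membered aromatic ring nor the sulfur of phenylsulfanyl is needed for a number in this range, and a five-membered non-aromatic ring carrying a hydrogen-bond donor can stand in the same place. No measurement at hand explains why the two groups read alike.

A plain cyclopentyl group would show whether the hydroxyl of 1-hydroxycyclopentyl matters at all. A methyl group or an amine at this place would test how far the group can depart from these two before the number shifts beyond the scatter.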